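The source may hold more compounds than are shown below. What is called first, only, known or untested is meant among the compounds shown, and "the series" means these compounds.

Measured in a functional assay on NCI-H1975 cells (Homo sapiens) for antiproliferative activity; a higher number here means a weaker inhibitor, a lower number a stronger inhibitor:
compound 1 `Cc1c2c(n3c1CCNC[C@@H](C)[C@H](C)Nc1cc-3ccc1C(N)=O)CC(C)(C)CC2=O`: 27 nM
compound 2 `Cc1c2c(n3c1CCN(C)C[C@@H](C)[C@H](C)Nc1cc-3ccc1C(N)=O)CC(C)(C)CC2=O`: 27 nM
compound 3 `Cc1c2c(n3c1CCN(C(=O)CN)C[C@@H](C)[C@H](C)Nc1cc-3ccc1C(N)=O)CC(C)(C)CC2=O`: 190 nM

Compound 3, at 190 nM, has the highest number of the three. The next compound is compound 4 `Cc1c2c(n3c1CCN(C(=O)C(C)(C)N)C[C@@H](C)[C@H](C)Nc1cc-3ccc1C(N)=O)CC(C)(C)CC2=O`, with 1-amino-1-methylethyl in place of aminomethyl on a carbonyl carbon.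

The nearest evidence comes from changes on the ring amine nitrogen. The (aminomethyl)carbonyl group gave a 7.0-fold higher number from compound 1 to compound 3 (0.85 log units; beyond the scatter) and a 7.0-fold higher number from compound 2 to compound 3 (0.85 log units; beyond the scatter), while methyl gave no change at the digits printed from compound 1 to compound 2 (within the scatter). Among the measured compounds shown here, no measured step alters the (aminomethyl)carbonyl group itself, so these steps bear on the change only indirectly, and no large shift is assumed.

The expected step is a 1.3-fold lower number from compound 3 to compound 4 (0.10 log units; within the scatter), with no move beyond the scatter anticipated. For compound 4 the estimate is 150 nM, with an expected range of 55 nM to 450 nM.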

Compound 4, half-maximal inhibitory concentration: 21 nM
Compound 4: the middle estimate sits 7.1-fold (0.85 log units) above what was measured, and the stated range ends above it.
By their numbers in this assay, from the lowest: compounds 4, 1 and 2 (each within the scatter of the next); then compound 3.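

In this assay, the acyl group on the ring amine nitrogen proves sensitive to substitution: 1-amino-1-methylethyl in place of aminomethyl gives a 9.0-fold lower number from compound 3 to compound 4 (0.96 log units; beyond the scatter), so the loss seen with (aminomethyl)carbonyl does not extend to every acyl group at this position. The (1-amino-1-methylethyl)carbonyl group is tolerated relative to the smaller nitrogen substituents, with a 1.3-fold lower number from compound 2 to compound 4 (0.11 log units; within the scatter) and a 1.3-fold lower number from compound 1 to compound 4 (0.11 log units; within the scatter). No available measurement explains the difference between the two acyl groups.

Open, on these data alone, is whether a single added methyl, as in 1-aminoethyl, is enough to produce this step. Also open, as far as these compounds go, is whether the amine is needed at all, a question an acetyl group on the same nitrogen would address.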